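The source may hold more compounds than are shown below. What is called first, only, known or untested is meant among the compounds shown, and "the series" means these compounds.

Measured so far:
compound 1, `CCCCn1cnc2[nH]c(=O)[nH]c(=O)c21`, in an assay on cell membranes from brain for binding affinity to adenosine receptor A1 (Rattus norvegicus), read by radioligand binding (on this read-out higher numbers stand for weaker inhibition and lower numbers for stronger inhibition), gives 27000 nM;
compound 2, `C=CCn1cnc2c1c(=O)[nH]c(=O)n2CC=C`, gives 36000 nM;
compound 3, `CC(=O)Cn1c(=O)[nH]c2[nH]c(C3CCCC3)nc2c1=O`, gives 2500 nM.

Among these three numbers compound 1 stands second highest. Its nearest neighbour is compound 2, and the two values lie within the usual scatter of the measurement, so nothing separates them. Compound 3 lies furthest away, with a clearly lower number beyond the scatter.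

Compound 4, `Cn1cnc2[nH]c(=O)[nH]c(=O)c21`, differs from compound 1 in one place: hydrogen in place of propyl on a saturated chain carbon bound to an aromatic nitrogen. Within the data shown here, no measured pair shows this kind of change, so the expected size of the step rests on judgement alone. A modest weakening seems the likeliest outcome, though a step within the scatter cannot be ruled out. The step from compound 1 to compound 4 is estimated as a 2.2-fold higher number from compound 1 to compound 4 (0.35 log units; beyond the scatter). Compound 4 is therefore expected to give about 60000 nM, within a range from 20000 nM to 200000 nM.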

Compound 4, inhibition constant: 33000 nM
Beside the measured number, compound 4's estimate is 1.8-fold (0.26 log units) above it; low and high end bracket the measured number.
By their numbers in this assay, from the lowest: compound 3; then compounds 1, 4 and 2 (each within the scatter of the next).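

In this assay, the change from butyl to methyl on the aromatic nitrogen of the shared core gives a 1.2-fold higher number from compound 1 to compound 4 (0.09 log units; within the scatter). This single pair therefore shows no separable effect of this change in chain length at this position. Nothing available explains this result. From the compounds shown here alone, whether a longer chain, such as octyl, or an amine or a carboxylic acid at the end of the chain would give a different number remains open. So does whether this result would hold on a core carrying other groups.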